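From Compound 2 to a 2-Cyclopropylpyridin-4-yl Analogue

This account rests on a few compounds, and the source may have more. Where it says the series, first, only, none or still open, it means among the compounds named here.

In a physicochemical assay for lipophilicity (on this read-out higher numbers stand for higher lipophilicity and lower numbers for lower lipophilicity), compound 1 (`C[C@H](NC(=O)c1cc(C(F)(F)F)nn1C)c1nc(-c2ccnc(N3CCCC3)c2)no1`) gives 4.2 and compound 2 (`COc1cc(-c2noc([C@H](C)NC(=O)c3cc(C(F)(F)F)nn3C)n2)cc(C)n1`) gives 4.4, two numbers within the scatter of each other. Compound 3 (`C[C@H](NC(=O)c1cc(C(F)(F)F)nn1C)c1nc(-c2ccnc(C3CC3)c2)no1`) has not yet been measured. It carries 2-cyclopropylpyridin-4-yl in place of 2-methoxy-6-methylpyridin-4-yl on an aromatic carbon of the shared core: 2-cyclopropylpyridin-4-yl in place of 2-methoxy-6-methylpyridin-4-yl on an aromatic carbon. For the measured compounds named here, no measured pair of compounds shows this change on its own, so the expectation is a cautious one. A small downward move in this assay, not beyond the scatter, is expected, with an estimated a number 0.20 log units lower from compound 2 to compound 3 (within the scatter). For compound 3 the estimated value is 4.2, with an expected range of 3.8 to 4.6.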

Compound 3, distribution coefficient: 4.1
The estimate for compound 3 lay 0.10 log units above the measured number; low and high end bracket the measured number.
By their numbers in this assay, from the lowest: compounds 3, 1 and 2 (each within the scatter of the next).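

In this assay, 2-cyclopropylpyridin-4-yl in place of 2-methoxy-6-methylpyridin-4-yl gives a step within the scatter (a number 0.30 log units lower from compound 2 to compound 3 (within the scatter)), and cyclopropyl in place of pyrrolidin-1-yl on an aromatic carbon does the same (a number 0.10 log units lower from compound 1 to compound 3 (within the scatter)). All three groups at this position thus stand within the scatter of one another, so neither swap separates them on this read-out. Nothing available accounts for these steps. From the compounds shown here alone, whether a carboxylic acid or a primary amine in place of the cyclopropyl would give a step beyond the scatter remains open.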